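The compounds below may be only part of what the source reports. "The series", "measured", "known", "first", "only" and "open" are said of these compounds alone.

Measured compounds:
- compound 1, `CC1CCN(c2c(S(=O)(=O)c3ccc(F)c(Cl)c3)cnc3cc(F)ccc23)CC1` — 94%
- compound 2, `CC1CCN(c2c(S(=O)(=O)c3ccccc3)cnc3cc(F)ccc23)CC1` — 87%
- compound 3, `CC1CCN(c2c(S(=O)(=O)c3ccc(F)c(Cl)c3)cnc3ccc(F)cc23)CC1` — 95%

Three compounds have been run through an assay on isolated protein for displacement of a labelled ligand from metabotropic glutamate receptor 5 (Homo sapiens), with a stated time of 60 min, tested at 1 uM; on this read-out lower numbers stand for less inhibition and higher numbers for more inhibition at the one concentration tested (going by the name of the read-out). For the measured compounds named here, compound 1 gives 94%, compound 2 gives 87% and compound 3 gives 95% in this assay; all three numbers sit close together, and no pair of them is separated by more than the usual scatter of this assay.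

Compound 1 and compound 2 share one core and differ in a single place, the change being (phenyl in place of 3-chloro-4-fluorophenyl on a sulfonyl sulfur). The step that this change made is a number 7 percentage points lower from compound 1 to compound 2 (within the scatter).

Compound 3 carries a core with the same atoms as compound 1, joined differently; the difference between the two cores is not broken down here. Compound 4, `CC1CCN(c2c(S(=O)(=O)c3ccccc3)cnc3ccc(F)cc23)CC1`, has not yet been measured in this assay. It stands to compound 3 as compound 2 stands to compound 1: the change is phenyl in place of 3-chloro-4-fluorophenyl on a sulfonyl sulfur, the same change made on the other core, the place being described in the same words in both cases.

Given that the one measured instance of this change on the other core, a number 7 percentage points lower from compound 1 to compound 2 (within the scatter), stayed within the scatter, compound 4 is expected to show a step of a number 7 percentage points lower from compound 3 to compound 4 (within the scatter), again a small one, because compound 3 starts from 95%. Compound 4 is therefore estimated at 88% in this assay, with the likely range running from 78% to 95%.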

Compound 4, a percentage reported as inhibition, at one concentration (the size of the read-out at that concentration, not a potency): 40%
Beside the measured number, compound 4's estimate is 48 percentage points above it, and the stated range ends above it.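

Phenyl in place of 3-chloro-4-fluorophenyl on a sulfonyl sulfur does not behave as one portable step in this assay, since the size of its effect differs between the two cores: the same change on two cores in this assay, a number 7 percentage points lower (within the scatter) from compound 1 to compound 2 and a number 55 percentage points lower (beyond the scatter) from compound 3 to compound 4, 48 percentage points apart, beyond the scatter of two such steps. On the core of compound 3, the change gives a number 55 percentage points lower from compound 3 to compound 4 (beyond the scatter), so a small step on one core was no safe guide to the step on the other in this pair of cores. For the compounds shown here, this does not show why the two cores part ways, nor how the change would behave on any further core, as each core offers only a single matched pair and each reading is taken at one concentration and is not a potency.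

The compounds shown leave open whether a phenyl carrying only the chlorine or only the fluorine would hold the reading of compound 3 or fall towards that of compound 4. They also leave open how this assay would respond to a nitrile or a methoxy group on that ring, and what full concentration-response curves would show for compound 3 and compound 4.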